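The compounds below may be only part of what the source reports. "The series", "measured", "known", "first", "only" and "open" are said of these compounds alone.

Notes on the series. Compound 1 `O=c1cc(-c2ccccc2)oc2cc(OCCCCNc3nc4ccccc4s3)cc(O)c12` and compound 2 `Cc1ccc2nc(NCCCCOc3cc(O)c4c(=O)cc(-c5ccccc5)oc4c3)sc2c1` share one core. In a physicochemical assay, read by spectrophotometry, with a stated time of 10 min (on this read-out lower numbers stand for stronger inhibition and higher numbers for weaker inhibition), compound 1 gives 8.57 ug/mL and compound 2 gives 8.79 ug/mL. Within the data shown here, the only measured step, a 1.0-fold higher number from compound 1 to compound 2 (0.01 log units; within the scatter), lies within the scatter, so the two numbers cannot be ordered and compound 2 simply sits beside compound 1 in this assay.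

Compound 3 `O=c1cc(-c2ccccc2)oc2cc(OCCCCNc3nc4ccc([N+](=O)[O-])cc4s3)cc(O)c12` differs from compound 2 by nitro in place of methyl on an aromatic carbon. Among the measured compounds shown here, the step from compound 1 to compound 2 is the only measured change on that aromatic ring, and it was flat; it bears on the new change only in that one exchange of substituent there left this assay unmoved. Nothing measured speaks to a nitro group itself. The expectation for compound 3 is therefore a step of about a 1.0-fold higher number from compound 2 to compound 3 (0.00 log units; within the scatter), with no clear direction. Compound 3 is estimated at 8.8 ug/mL, between 4.5 ug/mL and 17 ug/mL.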

Compound 3, half-maximal inhibitory concentration: 8.14 ug/mL
Estimate against measurement, compound 3: 1.1-fold (0.03 log units) above, and the stated range covers the measured number.
By their numbers in this assay, from the lowest: compounds 3, 1 and 2 (each within the scatter of the next).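

Working in this assay, nitro in place of methyl gives a 1.1-fold lower number from compound 2 to compound 3 (0.03 log units; within the scatter) and nitro in place of hydrogen on the same aromatic carbon gives a 1.1-fold lower number from compound 1 to compound 3 (0.02 log units; within the scatter). Both steps lie within the scatter, so the position now holds hydrogen, methyl and nitro with no ordering among compound 1, compound 2 and compound 3, and the flatness seen earlier extends to a group with oxygen and nitrogen atoms and hydrogen-bond acceptors. Nothing available accounts for this flat result.

Still open, as far as these compounds go, is whether an amine or a carboxylic acid on this aromatic carbon would leave the number equally unmoved. Among these compounds, also open is whether a longer chain in place of the one shared by these compounds would move it, and whether the substituent matters on another carbon of that ring.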